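Ester swap on a second core: what one step suggests

The source may hold more compounds than are shown below. What is called first, only, known or untested is meant among the compounds shown, and "the series" means these compounds.

Compound 1 `C=C1[C@H](OC(C)=O)[C@@H](OC(C)=O)[C@@H](OC(C)=O)C(C)(C)/C=C/[C@H](C)[C@H](OC(=O)c2ccccc2)[C@@]2(O)C[C@@](C)(OC(C)=O)[C@H](OC(C)=O)[C@@H]2[C@H]1OCC(C)C` is a heavily acetylated polycyclic natural-product-like scaffold. In a functional assay on NCI/ADR-RES cells (Homo sapiens) for positive allosteric modulation, read by MTT assay, with a stated time of 48 h, tested at 10 uM (on this read-out lower numbers stand for stronger inhibition and higher numbers for weaker inhibition), compound 1 gives 4810 nM. Compound 2 `C=C1[C@H](OC(C)=O)[C@@H](OC(C)=O)[C@@H](OC(C)=O)C(C)(C)/C=C/[C@H](C)[C@H](OC(=O)c2ccccc2)[C@@]2(O)C[C@@](C)(OC(=O)c3cccc(C)c3)[C@H](OC(C)=O)[C@@H]2[C@H]1OCC(C)C` carries one change, (3-methylphenyl in place of methyl on a carbonyl carbon), and in this assay compound 2 gives 1510 nM. That change produced a 3.2-fold lower number from compound 1 to compound 2 (0.50 log units; beyond the scatter).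

Compound 3 `C=C1[C@H](OC(C)=O)[C@@H](OC(C)=O)[C@@H](OC(C)=O)C(C)(C)/C=C/[C@H](C)[C@H]2O[C@]3(C)C[C@@]2(OC(=O)c2ccccc2)[C@H]([C@H]3OC(C)=O)[C@H]1OCC(C)C` has a different core; how the two cores differ is not broken down here. In this assay compound 3 gives 1700 nM, close to compound 2 and well apart from compound 1.

Compound 4 `C=C1[C@H](OC(C)=O)[C@@H](OC(=O)c2cccc(C)c2)[C@@H](OC(C)=O)C(C)(C)/C=C/[C@H](C)[C@H]2O[C@]3(C)C[C@@]2(OC(=O)c2ccccc2)[C@H]([C@H]3OC(C)=O)[C@H]1OCC(C)C` is not yet measured. It differs from compound 3 by 3-methylphenyl in place of methyl on a carbonyl carbon, the same change seen between compound 1 and compound 2, at a place described in the same words. The cores differ, and the earlier step is taken as a guide rather than a rule. A somewhat smaller step is expected: for compound 4 the estimated change is a 2.0-fold lower number from compound 3 to compound 4 (0.30 log units; within the scatter). In this assay compound 4 is therefore expected to give about 850 nM, with a range of 400 nM to 2200 nM considered likely.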

Compound 4, half-maximal inhibitory concentration: 6570 nM
The estimate for compound 4 lay 7.7-fold (0.89 log units) below the measured number, outside the stated range (above it).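

In this assay, replacing acetoxy with ((3-methylphenyl)carbonyl)oxy gives a 3.9-fold higher number from compound 3 to compound 4 (0.59 log units; beyond the scatter), and setting this beside the earlier step shows that the same change went opposite ways on the two cores: the same change on two cores in this assay, a 3.2-fold lower number (0.50 log units; beyond the scatter) from compound 1 to compound 2 and a 3.9-fold higher number (0.59 log units; beyond the scatter) from compound 3 to compound 4, 12-fold (1.09 log units) apart, beyond the scatter of two such steps.
So in this series, the effect of this change on one core did not predict its effect on the other. For the compounds shown here, it does not show what separates the two results: the acetoxy group replaced in compound 4 is not the one replaced in compound 2, and with a single pair on each core, the influence of the core cannot be told apart from that of the site.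

The compounds shown leave open how the swap behaves when made at the matching acetoxy group on both cores. They also leave open whether a different ester, such as hexanoyl with its longer chain or one carrying an amine, would split the two cores in the same way.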